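The source may hold more compounds than are shown below. What is called first, only, known or untested is meant among the compounds shown, and "the series" means these compounds.

The three measured compounds are built on the shared core. Compound 1 `C/C=C(\C)[C@H]1OC(=O)[C@@H](C)NC(=O)[C@H]([C@@H](C)CC)NC(=O)CN(C)C(=O)[C@@H](Cc2ccccc2)N(C)C(=O)[C@H](C)NC(=O)[C@@H](CC(C)C)OC(=O)/C(C)=C/C[C@H](O)[C@@H]1C` in a functional assay on A549 cells (Homo sapiens) for cytotoxicity, read by CellTiter-Blue, with a stated time of 72 h (on this read-out lower numbers stand for stronger inhibition and higher numbers for weaker inhibition), gives 0.0021 nM. Compound 2 `C/C=C(\C)[C@H]1OC(=O)[C@@H](C)NC(=O)[C@H]([C@@H](C)CC)NC(=O)CN(C)C(=O)[C@@H](Cc2ccccc2)N(C)C(=O)[C@H](C)NC(=O)[C@@H](CC(C)C)OC(=O)/C(C)=C/C[C@H](OCSC)[C@@H]1C` in this assay gives 0.00019 nM, the lowest of the three numbers; the step of an 11-fold lower number from compound 1 to compound 2 (1.04 log units; beyond the scatter) is (methylsulfanyl)methyl in place of hydrogen on an oxygen on a saturated carbon. Compound 3 `C/C=C(\C)[C@H]1OC(=O)[C@@H](C)NC(=O)[C@H]([C@@H](C)CC)NC(=O)CN(C)C(=O)[C@@H](Cc2ccccc2)N(C)C(=O)[C@@H](C)NC(=O)[C@@H](CC(C)C)OC(=O)/C(C)=C/C[C@H](OCSC)[C@@H]1C` in this assay gives 4340 nM, and the step of a 23000000-fold higher number from compound 2 to compound 3 (7.36 log units; beyond the scatter) rests on (the fact that compounds 2 and 3 differ only in the configuration as drawn).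

Compound 4 `C/C=C(\C)[C@H]1OC(=O)[C@@H](C)NC(=O)[C@H]([C@@H](C)CC)NC(=O)CN(C)C(=O)[C@@H](Cc2ccc(Cl)cc2)N(C)C(=O)[C@H](C)NC(=O)[C@@H](CC(C)C)OC(=O)/C(C)=C/C[C@H](OCSC)[C@@H]1C` differs from compound 2 by chloro in place of hydrogen on an aromatic carbon. Neither measured step touches the aromatic ring: one alters a group on an oxygen on a saturated carbon, the other a configuration, and both are large. Nothing measured here speaks directly to chloro on the aromatic carbon, so in this assay no step beyond the scatter is expected in either direction. Compound 4 is therefore expected to give about 0.0003 nM, between 0.00005 nM and 0.002 nM. This estimate amounts to an expected step of a 1.6-fold higher number from compound 2 to compound 4 (0.20 log units; within the scatter).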

Compound 4, half-maximal inhibitory concentration: 0.73 nM
For compound 4 the middle estimate is 2400-fold (3.39 log units) below the measured one; measured number outside the range, above it.
By their numbers in this assay, from the lowest: compound 2; then compound 1; then compound 4; then compound 3.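

In this assay, the step of a 3800-fold higher number from compound 2 to compound 4 (3.58 log units; beyond the scatter) shows that the aromatic ring, which neither earlier step touched, is also a sensitive place on this molecule. Adding a single chlorine atom, which turns benzyl into 4-chlorobenzyl, is enough to produce a large loss of activity, so the changes at the oxygen and at the ring stereocentre are not the only single edits that matter here. Among these compounds, the only available evidence concerns a difference in configuration, so it does not bear on this chloro step, and the cause of the loss remains unexplained.

From the compounds shown here alone, it remains open whether this loss is specific to chloro or would also follow from fluoro, methyl or methoxy on the same aromatic carbon. It is also unclear whether chloro would have a similar effect on compound 1, which carries a free hydroxyl group.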